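Oxygen to Sulfur in the Aryl Linker of Compound 1

The source may hold more compounds than are shown below. What is called first, only, known or untested is meant among the compounds shown, and "the series" means these compounds.

Compound 1, `Nc1cc(N)c2nc(-c3ccccc3)c(Oc3ccc(Cl)c(Cl)c3)nc2c1`: 5620 nM
Compound 2, `CCOC(=O)[C@H](CCC(=O)O)NC(=O)c1ccc(Sc2nc3cc(N)cc(N)c3nc2-c2ccccc2)cc1`: 19100 nM
Compound 3, `COc1cc(CNc2nc3cc(N)cc(N)c3nc2-c2ccccc2)cc(OC)c1OC`: 16200 nM

Of the compounds shown here, three have so far been measured in a functional assay on SK-MEL-2 cells (Homo sapiens) for inhibition, read by sulforhodamine B assay, with a stated time of 48 h; a lower number here means a stronger inhibitor of growth, a higher number a weaker inhibitor of growth. Compound 1 gives the lowest number of the three; compound 3 stands nearest to it and compound 2 furthest, and both gaps lie beyond the usual scatter. Compound 4, `Nc1cc(N)c2nc(-c3ccccc3)c(Sc3ccc(Cl)c(Cl)c3)nc2c1`, has not yet been measured. It differs from compound 1 in one place: (3,4-dichlorophenyl)sulfanyl in place of 3,4-dichlorophenoxy on an aromatic carbon. Among the measured compounds shown here, compound 2 also carries a sulfanyl linkage, but its aryl part differs as well, so no step of exactly this kind has been measured. The expectation is a small step, a 1.1-fold lower number from compound 1 to compound 4 (0.05 log units; within the scatter), not clearly beyond the scatter in either direction. For compound 4 the estimated value is 5000 nM, with a range from 1800 nM to 14000 nM.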

Compound 4, concentration for 50% growth inhibition: 6170 nM
Estimate against measurement, compound 4: 1.2-fold (0.09 log units) below, and the stated range covers the measured number.
By their numbers in this assay, from the lowest: compounds 1 and 4 (each within the scatter of the next); then compounds 3 and 2 (each within the scatter of the next).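

In this assay, among the compounds shown here, the exchange of 3,4-dichlorophenoxy for (3,4-dichlorophenyl)sulfanyl gives a 1.1-fold higher number from compound 1 to compound 4 (0.04 log units; within the scatter) and is the first single-place comparison at this aromatic carbon. With the 3,4-dichlorophenyl group and the rest of the molecule kept, oxygen and sulfur as the linking atom read alike here. Nothing at hand explains this result. Compounds 2 and 3 differ from both in more than one place, so they add no comparison at this position. On these data alone, whether a sulfonyl or methylene linker would read the same remains open.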